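Adding an Acetyl Group to a Sulfonamide Nitrogen

The source may report more compounds than this note shows. Statements on the series, on what has been measured and on what is new or still open speak of the compounds shown alone.

Compound 1 `COc1ccc(OC)c(-c2cc(-c3ccc(Cl)cc3)nn2-c2ccc(S(=O)(=O)NC(C)=O)cc2)c1`: 8180 nM
Compound 2 `Oc1ccc(O)c(-c2cc(-c3ccc(Cl)cc3)nn2-c2ccccc2)c1`: 5750 nM
Compound 3 `NS(=O)(=O)c1ccc(-n2nc(-c3ccc(Cl)cc3)cc2-c2cc(O)ccc2O)cc1`: 15100 nM

In a functional assay on cells (Cancer cell lines, Homo sapiens) for cytotoxicity, read by sulforhodamine B assay, with a stated time of 48 h (on this read-out lower numbers stand for stronger inhibition of growth and higher numbers for weaker inhibition of growth), compound 3 gives the highest of the three numbers; compound 1 lies within the scatter of it, whereas a 2.6-fold higher number from compound 2 to compound 3 (0.42 log units; beyond the scatter) lies beyond the scatter. Compound 4 `CC(=O)NS(=O)(=O)c1ccc(-n2nc(-c3ccc(Cl)cc3)cc2-c2cc(O)ccc2O)cc1` differs from compound 3 by acetyl in place of hydrogen on a sulfonamide nitrogen. Going by the values given here, no measured pair isolates this change. Compound 1 carries the same acetylsulfamoyl group, though on a ring bearing methoxy rather than hydroxy groups, and its number sits within the scatter of compound 3. Among the compounds with values here, the only measured step on this sulfonamide-bearing ring, hydrogen to sulfamoyl, pushed the number modestly upward. With nothing pointing firmly either way, compound 4 is expected to stay near compound 3, a step of a 1.3-fold lower number from compound 3 to compound 4 (0.10 log units; within the scatter) that remains within the scatter. The estimate for compound 4 is 12000 nM, ranging from 5000 nM to 30000 nM.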

Compound 4, concentration for 50% growth inhibition: 37600 nM
Beside the measured number, compound 4's estimate is 3.1-fold (0.50 log units) below it; the measured number lies above the stated range.
By their numbers in this assay, from the lowest: compounds 2, 1 and 3 (each within the scatter of the next, the first and the last beyond it); then compound 4.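

Within this assay the acetyl group on the sulfonamide nitrogen weakens growth inhibition: a 2.5-fold higher number from compound 3 to compound 4 (0.40 log units; beyond the scatter) is the first step that isolates this change. Acetylsulfamoyl in place of hydrogen on an aromatic carbon gives a 6.5-fold higher number from compound 2 to compound 4 (0.82 log units; beyond the scatter) and 2,5-dihydroxyphenyl in place of 2,5-dimethoxyphenyl gives a 4.6-fold higher number from compound 1 to compound 4 (0.66 log units; beyond the scatter) so compound 4 is the weakest of the four. Nothing measured here explains these steps.
Still open, as far as these compounds go, is whether a longer chain such as propionyl, or a small methyl group, on that nitrogen would shift the number the same way.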